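Sulfanyl aryl change: methoxy to bromo

This account rests on a few compounds, and the source may have more. Where it says the series, first, only, none or still open, it means among the compounds named here.

In a functional assay on DU-145 cells (Homo sapiens) for inhibition, read by trypan blue exclusion, with a stated time of 96 h (on this read-out lower numbers stand for stronger inhibition of growth and higher numbers for weaker inhibition of growth), compound 1 (`O=C(/C(=C\c1ccccc1OCc1ccccc1)S(=O)(=O)Cc1ccc(F)cc1)c1ccc(Cl)cc1`) gives 10000 nM and compound 2 (`COc1ccc(S/C(=C/c2ccccc2OCc2ccccc2)C(=O)c2ccc(Cl)cc2)cc1`) gives 1000 nM as the lower of the two numbers. Compound 3 (`O=C(/C(=C\c1ccccc1OCc1ccccc1)Sc1ccc(Br)cc1)c1ccc(Cl)cc1`) has bromo in place of methoxy on an aromatic carbon and keeps the rest of compound 2. Among the measured compounds shown here, the only measured step (a 10-fold lower number from compound 1 to compound 2 (1.00 log units; beyond the scatter)) exchanges the whole sulfur-bound group, so it bears only loosely on this smaller change. No step beyond the scatter is expected in this assay, and the estimated step (a 1.3-fold lower number from compound 2 to compound 3 (0.10 log units; within the scatter)) has no firm direction. Compound 3 is estimated at 800 nM with a range from 200 nM to 3500 nM as expected bounds.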

Compound 3, concentration for 50% growth inhibition: 10000 nM
Compound 3: the middle estimate sits 13-fold (1.10 log units) below what was measured; the measured number lies above the stated range.
By their numbers in this assay, from the lowest: compound 2; then compounds 1 and 3 (each within the scatter of the next).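

In this assay, bromo in place of methoxy on this aromatic carbon alone gives a clear loss (a 10-fold higher number from compound 2 to compound 3 (1.00 log units; beyond the scatter)), so the lower number of compound 2 depends on the group at this position and not only on the sulfanyl link. The sulfur-bound exchange with the (4-bromophenyl)sulfanyl group gives nothing (no change at the digits printed from compound 1 to compound 3 (within the scatter)), so replacing the (4-fluorobenzyl)sulfonyl group is not enough by itself. No available evidence accounts for this difference between methoxy and bromo. Going by these compounds, what an amine or a hydroxy group on this aromatic carbon would give remains open. Also open, on these data alone, is whether a longer alkoxy chain would keep the number of compound 2.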